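From isobutylcarbonyl to butyl on a shared core

This account rests on a few compounds, and the source may have more. Where it says the series, first, only, none or still open, it means among the compounds named here.

Two compounds with the same core differ only in the group on an oxygen on an aromatic ring. In a functional assay on DLD-1 cells (Homo sapiens) for cytotoxicity, with a stated time of 48 h (a higher number here means a weaker inhibitor, a lower number a stronger inhibitor), compound 1 `CCOc1ccc2oc(/C=C/[S+](C)[O-])cc(=O)c2c1` gives 4900 nM, and compound 2 `CC(C)CC(=O)Oc1ccc2oc(/C=C/[S+](C)[O-])cc(=O)c2c1` gives 6100 nM. Among the compounds with values here, these two numbers lie within the scatter of each other, so compound 2 stands level with the only other compound measured.

The next structure, compound 3 `CCCCOc1ccc2oc(/C=C/[S+](C)[O-])cc(=O)c2c1`, changes the same place: butyl in place of isobutylcarbonyl on an oxygen on an aromatic ring. Butyl thus replaces isobutylcarbonyl on that oxygen.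

Within the data shown here, one measured step bears on this swap, since it also changes only the group on that oxygen: a 1.2-fold higher number from compound 1 to compound 2 (0.10 log units; within the scatter). Replacing ethyl with isobutylcarbonyl therefore left the number within the scatter. Two compounds are thin evidence, but no step beyond the scatter is expected in this assay, in either direction. The expected step is a 1.2-fold lower number from compound 2 to compound 3 (0.09 log units; within the scatter). For compound 3 the estimated value is 5000 nM, with an expected range from 2200 nM to 11000 nM.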

Compound 3, half-maximal inhibitory concentration: 4800 nM
Compound 3: middle estimate off by 1.0-fold (0.02 log units), on the high side; the measured number falls inside the stated range.
By their numbers in this assay, from the lowest: compounds 3, 1 and 2 (each within the scatter of the next).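

In this assay, the swap from isobutylcarbonyl to butyl on an oxygen on an aromatic ring gives a 1.3-fold lower number from compound 2 to compound 3 (0.10 log units; within the scatter) even though it removes the carbonyl, so this group with its one hydrogen-bond acceptor and a group with none read the same here. The other new comparison, butyl against ethyl, gives a 1.0-fold lower number from compound 1 to compound 3 (0.01 log units; within the scatter) and adds a second kind of change at this position, a longer plain chain, which the first two compounds could not show. Across ethyl, isobutylcarbonyl and butyl, then, the number stays level in this cell assay, and no measurement shown explains why.

On these data alone, all three groups are modest and uncharged, so it remains open whether this position tolerates everything or only groups of this kind: a free hydroxyl, a much longer chain such as octyl, a chain ending in an amine or a carboxylic acid, or a benzyl group could each behave differently. As far as these compounds go, whether the same level reading holds in other cell lines also stays open.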